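The source may hold more compounds than are shown below. What is called first, only, known or untested is meant among the compounds shown, and "the series" means these compounds.

Measured so far in a functional assay on SF-539 cells (Homo sapiens) for inhibition, read by sulforhodamine B assay, with a stated time of 48 h, tested at 0.01 uM; on this read-out higher numbers stand for a weaker effect at the one concentration tested and lower numbers for a stronger effect:
compound 1, `O=C(Nc1cccc(-n2cc(-c3ccncc3)c(-c3cc(O)cc(Cl)c3)n2)c1)Nc1ccc(Cl)c(C(F)(F)F)c1`: 104%
compound 2, `O=C(Nc1cccc(-n2cc(-c3ccncc3)c(-c3cc(O)cc(Cl)c3)n2)c1)Nc1ccc(Cl)c(Cl)c1`: 59%
compound 3, `COc1cc(Cl)cc(-c2nn(-c3cccc(NC(=O)Nc4ccc(Cl)c(C(F)(F)F)c4)c3)cc2-c2ccncc2)c1`: 96%

Compound 3 sits in the upper part of these three numbers. Against compound 1 its reading cannot be told apart, the step being within the scatter (a number 8 percentage points lower from compound 1 to compound 3 (within the scatter)), whereas the gap between compound 3 and compound 2 lies beyond the scatter, compound 2 giving the lower of the two readings.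

The next member is compound 4, `COc1cc(Cl)cc(-c2nn(-c3cccc(NC(=O)Nc4ccc(Cl)c(Cl)c4)c3)cc2-c2ccncc2)c1`. It differs from compound 3 in one place: chloro in place of trifluoromethyl on an aromatic carbon.

Among the compounds with values here, one measured step bears directly on this change, since it is the same exchange made on the parent pair: a number 45 percentage points lower from compound 1 to compound 2 (beyond the scatter). That step was large and downward, well beyond the scatter. The methyl ether of compound 3 did not shift the reading against compound 1 (a number 8 percentage points lower from compound 1 to compound 3 (within the scatter)), so there is no sign from the data that it would alter how the chloro-for-trifluoromethyl exchange plays out. The expected step is therefore of similar size and the same direction, a number 42 percentage points lower from compound 3 to compound 4 (beyond the scatter), a drop beyond the scatter in this assay.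

On that basis compound 4 is estimated at 54% in this assay, with a range of 34% to 78%.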

Compound 4, a percentage reported as activity, at one concentration (the size of the read-out at that concentration, not a potency): 100%
Compound 4: the middle estimate sits 46 percentage points below what was measured; the whole stated range lies below it.
By their numbers in this assay, from the lowest: compound 2; then compounds 3, 4 and 1 (each within the scatter of the next).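

In this assay, the change from 4-chloro-3-(trifluoromethyl)phenyl to 3,4-dichlorophenyl turns out to depend on the core that carries it, since on the methyl ether it gives a number 4 percentage points higher from compound 3 to compound 4 (within the scatter) and not the large drop seen with the free hydroxyl: the same change on two cores in this assay, a number 45 percentage points lower (beyond the scatter) from compound 1 to compound 2 and a number 4 percentage points higher (within the scatter) from compound 3 to compound 4, 49 percentage points apart, beyond the scatter of two such steps.

The methyl on the oxygen, which made no readable difference while trifluoromethyl was present, gives a number 41 percentage points higher from compound 2 to compound 4 (beyond the scatter) once chloro stands in its place: the same change on two cores in this assay, a number 8 percentage points lower (within the scatter) from compound 1 to compound 3 and a number 41 percentage points higher (beyond the scatter) from compound 2 to compound 4, 49 percentage points apart, beyond the scatter of two such steps.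

The two changes therefore cannot be read singly in this series, as the lower reading appears only where the 3,4-dichlorophenyl group and the free hydroxyl occur together in compound 2, and compound 4 goes against any rule that chloro at this position lowers the number on its own.

Still open, as far as these compounds go, is whether this dependence is specific to the hydroxyl hydrogen, which an amine in place of the hydroxyl or an ethyl ether would test, and whether a bromo or nitrile group at the position of the chloro would pair with the hydroxyl in the same way. From the compounds shown here alone, these readings speak only of a stronger or weaker effect at the one concentration tested, and what other concentrations would show stays open.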